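A few compounds are considered here, and "the series" means these few. Any claim that something is new, unique, unknown or untested is made for them only; others in the source may bear on it.

Of the compounds shown here, three sharing one core have been tested in a functional assay on HepG2 cells (Homo sapiens) for inhibition, read by MTT assay, with a stated time of 3 days; a lower number here means a stronger inhibitor, a higher number a weaker inhibitor. Compound 1 `COc1cc(-c2nc3ccccc3s2)ccc1OCC(=O)NNC(=O)CCl` carries a chloro group on a saturated chain carbon bound to a carbonyl carbon, and in this assay compound 1 gives 2890 nM. Compound 2 `CC[C@H](C)[C@H](NCC(=O)NNC(=O)COc1ccc(-c2nc3ccccc3s2)cc1OC)C(=O)O` has a (1-carboxy-2-methylbutyl)amino group at that position in place of chloro, and compound 2 gives 3540 nM. Compound 3 `CCOC(=O)CN(C)CC(=O)NNC(=O)COc1ccc(-c2nc3ccccc3s2)cc1OC` has a ((ethoxycarbonyl)methyl)(methyl)amino group there, and compound 3 gives 3180 nM. Compound 2 has the highest of the three numbers, but the steps of a 1.2-fold higher number from compound 1 to compound 2 (0.09 log units; within the scatter) and a 1.1-fold lower number from compound 2 to compound 3 (0.05 log units; within the scatter) both fall within the scatter, so no real separation among the three can be claimed.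

Compound 4 `CCOC(=O)[C@H](NCC(=O)NNC(=O)COc1ccc(-c2nc3ccccc3s2)cc1OC)[C@@H](C)CC` differs from compound 2 in one place: 1-(ethoxycarbonyl)-2-methylbutyl in place of 1-carboxy-2-methylbutyl on an amine nitrogen. The measured steps bear on this in two ways. The step of a 1.2-fold higher number from compound 1 to compound 2 (0.09 log units; within the scatter) shows that attaching the amino acid to the core leaves the number where it was, and the step of a 1.1-fold lower number from compound 2 to compound 3 (0.05 log units; within the scatter) shows that an ethoxycarbonyl-bearing amino group in place of the carboxy-bearing one also changes nothing beyond the scatter. Compound 4 is therefore expected to give a number close to that of compound 2, with a step of a 1.1-fold lower number from compound 2 to compound 4 (0.03 log units; within the scatter) in this assay. The estimate for compound 4 is 3300 nM, with a likely range from 1600 nM to 6800 nM.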

Compound 4, half-maximal inhibitory concentration: 3970 nM
For compound 4 the middle estimate is 1.2-fold (0.08 log units) below the measured one; low and high end bracket the measured number.
By their numbers in this assay, from the lowest: compounds 1, 3, 2 and 4 (each within the scatter of the next).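

Among the compounds shown here, compounds 2 and 4 are the first pair in which only the carboxy end of the amino acid side chain changes. The earlier comparison of compound 2 with compound 3 also altered the rest of the amino group. In this assay, replacing 1-carboxy-2-methylbutyl with 1-(ethoxycarbonyl)-2-methylbutyl on the amine nitrogen gives a 1.1-fold higher number from compound 2 to compound 4 (0.05 log units; within the scatter), so this change alone does not shift the number beyond the scatter. The wider comparisons agree, with a 1.2-fold higher number from compound 3 to compound 4 (0.10 log units; within the scatter) and a 1.4-fold higher number from compound 1 to compound 4 (0.14 log units; within the scatter), which places all four groups tried at this position within the scatter of one another, and no measurement at hand explains why these changes leave the number in place.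

These compounds leave open whether any group at this position can move the number beyond the scatter, since chloro and the three substituted amino groups give no separation. A simple unsubstituted amine in place of chloro, a ring amine such as morpholine, or a longer chain between the carbonyl and the amine nitrogen would each test this further.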